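Swapping the Pyrrolidinyl Arm for an Anilide

This account rests on a few compounds, and the source may have more. Where it says the series, first, only, none or still open, it means among the compounds named here.

Compound 1 `CN1CCN(c2ccc(Nc3ncc4nc(Nc5ccc(F)cc5)n([C@H]5CCN(C(=O)CO)C5)c4n3)cc2)CC1`: 380 nM
Compound 2 `CN1CCN(c2ccc(Nc3ncc4nc(Nc5ccccc5)n([C@@H]5CCN(S(=O)(=O)C6CC6)C5)c4n3)cc2)CC1`: 0.88 nM

Both compounds were examined in a functional assay on HCC827 cells (Homo sapiens) for antiproliferative activity, read by MTT assay, with a stated time of 72 h; a higher number here means a weaker inhibitor, a lower number a stronger inhibitor. Of the two numbers, compound 1 stands highest: in this assay compound 1 gives 380 nM, while compound 2 gives 0.88 nM, a gap well beyond the scatter. Among the compounds with values here, the two compounds differ in more than one place, so their values show only that the shared core can reach very low numbers.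

The step to compound 3 `CN1CCN(c2ccc(Nc3ncc4nc(Nc5ccc(F)cc5)n(-c5cccc(NC(=O)CO)c5)c4n3)cc2)CC1` alters a single place of compound 1: 3-(((hydroxymethyl)carbonyl)amino)phenyl in place of 1-((hydroxymethyl)carbonyl)pyrrolidin-3-yl on an aromatic nitrogen. Within the data shown here, no one-change step of this kind has been measured, so its size is uncertain. Because compound 2 gives 0.88 nM on the same core, headroom exists, and a moderate move to a lower number is expected, a 3.2-fold lower number from compound 1 to compound 3 (0.50 log units; beyond the scatter), though the direction itself remains unsupported by any measured step. Compound 3 is estimated at 120 nM, within a range of 20 nM to 700 nM.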

Compound 3, half-maximal inhibitory concentration: 7.5 nM
For compound 3 the middle estimate is 16-fold (1.20 log units) above the measured one; measured number outside the range, below it.
By their numbers in this assay, from the lowest: compound 2; then compound 3; then compound 1.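

At the aromatic nitrogen of the shared core, 3-(((hydroxymethyl)carbonyl)amino)phenyl in place of 1-((hydroxymethyl)carbonyl)pyrrolidin-3-yl gives, in this assay, a 51-fold lower number from compound 1 to compound 3 (1.70 log units; beyond the scatter), which shows that this single place can by itself move the number by a large step. The entering group has no defined stereocentre, and compound 3 still gives 7.5 nM, so a low number at this place does not depend on the stereocentre of the pyrrolidine ring. Nothing measured here bears on why the step is so large.

From the compounds shown here alone, it remains open how an acryloyl group in place of the (hydroxymethyl)carbonyl on the amino nitrogen would read. Also open, going by these compounds, is whether the same amide elsewhere on the phenyl ring would hold the low number.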